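The source may hold more compounds than are shown below. What is called first, only, known or untested is meant among the compounds shown, and "the series" means these compounds.

Working notes on the series. For the measured compounds named here, in a functional assay on A2780 cells (Homo sapiens) for antiproliferative activity, read by MTT assay, with a stated time of 48 h (on this read-out lower numbers stand for stronger inhibition of growth and higher numbers for weaker inhibition of growth), compound 3 (`COC(=O)N1N=C(c2cccc(O)c2)CC1c1cc(OC)c(OC)c(OC)c1`) gives 810 nM, the lowest of the three numbers so far and beyond the scatter from both others. Compound 1 (`CCOC(=O)N1N=C(c2cccc(OC)c2)CC1c1cc(OC)c(OC)c(OC)c1`) gives 7300 nM, and compound 2 (`CCOC(=O)N1N=C(c2ccc(OC)cc2)CC1c1cc(OC)c(OC)c(OC)c1`) gives 9270 nM. The next compound, compound 4 (`CCOC(=O)N1N=C(c2cccc(O)c2)CC1c1cc(OC)c(OC)c(OC)c1`), follows from compound 3 by methyl in place of hydrogen on a saturated chain carbon bound to an oxygen next to a carbonyl group, that is, methoxycarbonyl to ethoxycarbonyl. Going by the values given here, the only measured step, a 1.3-fold higher number from compound 1 to compound 2 (0.10 log units; within the scatter), is within the scatter and lies elsewhere in the structure, so no measured step isolates this change. Compound 1 and compound 2 carry ethoxycarbonyl but also differ from compound 3 in another place, so their numbers cannot be assigned to this change alone. Only a small move to a higher number in this assay is therefore expected, probably within the scatter. The expected step is a 1.6-fold higher number from compound 3 to compound 4 (0.21 log units; within the scatter). For compound 4 the estimated value is 1300 nM, with an expected range from 450 nM to 4500 nM.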

Compound 4, concentration for 50% growth inhibition: 9750 nM
The estimate for compound 4 lay 7.5-fold (0.88 log units) below the measured number; measured number above the stated range.
By their numbers in this assay, from the lowest: compound 3; then compounds 1, 2 and 4 (each within the scatter of the next).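

In this assay, this position is far from silent: methyl in place of hydrogen, methoxycarbonyl to ethoxycarbonyl, gives a 12-fold higher number from compound 3 to compound 4 (1.08 log units; beyond the scatter) and so accounts for the whole separation of compound 3 from the rest. With ethoxycarbonyl in place, the ring substituent does not separate the compounds: hydrogen in place of methyl on the aromatic oxygen gives a 1.3-fold higher number from compound 1 to compound 4 (0.13 log units; within the scatter) and 3-hydroxyphenyl in place of 4-methoxyphenyl gives a 1.1-fold higher number from compound 2 to compound 4 (0.02 log units; within the scatter) for this pair. The 3-hydroxyphenyl group thus goes with the low number only alongside methoxycarbonyl, and no supporting data bear on this step.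

Open, as far as these compounds go, is whether methoxycarbonyl would also lower the number with 3-methoxyphenyl or 4-methoxyphenyl. Also open, from the compounds shown here alone, is how a longer chain such as propoxycarbonyl, or a carboxylic acid at this place, would read.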